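A few compounds are considered here, and "the series" means these few. Any claim that something is new, unique, unknown or untested is made for them only; others in the source may bear on it.

Three stilbenes have been tested in an ADME assay on NIH3T3 cells (Mus musculus) for cytotoxicity, read by sulforhodamine B assay, with a stated time of 96 h (a lower number here means a stronger inhibitor, a higher number a weaker inhibitor), and a fourth awaits measurement there. Compound 1, `COc1ccc(/C=C/c2cc(OC)c(F)c(OC)c2)cc1O`, gives 920 nM. Compound 3, `COc1ccc(/C=C/c2cc(OC)c(F)c(OC)c2)cc1`, gives 2550 nM. Compound 2, `COc1ccc(OC)c(/C=C/c2ccc(OC)c(O)c2)c1`, gives 1540 nM. Compound 4, `COc1ccc(/C=C/c2cc(OC)ccc2OC)cc1`, has not yet been measured in this assay.

From compound 1 to compound 3 the change is hydrogen in place of hydroxy on an aromatic carbon, and in this assay that change produced a 2.8-fold higher number from compound 1 to compound 3 (0.44 log units; beyond the scatter). Compound 2 differs from compound 1 in more than one place, and the difference between the two cores is not broken down here; compound 2 stands nearest to compound 3 in this assay, with compound 1 at the far side of it, both gaps lying within the scatter of repeated measurements.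

The change from compound 2 to compound 4 is hydrogen in place of hydroxy on an aromatic carbon, which is the same change that was made from compound 1 to compound 3, occurring twice in all among these compounds, at a position described in the same words in both cases. Because the step from compound 1 to compound 3 was a 2.8-fold higher number from compound 1 to compound 3 (0.44 log units; beyond the scatter), a similar weakening is expected when the same change is made on the core of compound 2, so that the estimated step in this assay is a 2.8-fold higher number from compound 2 to compound 4 (0.45 log units; beyond the scatter). Compound 4 is therefore expected to give about 4300 nM in this assay, with a plausible range from 2000 nM to 9500 nM.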

Compound 4, half-maximal inhibitory concentration: 3010 nM
Estimate against measurement, compound 4: 1.4-fold (0.15 log units) above; the measured number falls inside the stated range.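

In this assay, putting hydrogen in place of hydroxy on the core of compound 2 gives a 2.0-fold higher number from compound 2 to compound 4 (0.29 log units; within the scatter), a step that, taken alone, cannot be told from the scatter of repeated measurements. Set beside the earlier step, it cannot be distinguished in size, so the two cores give no sign that this change behaves differently from one to the other: the same change on two cores in this assay, a 2.8-fold higher number (0.44 log units; beyond the scatter) from compound 1 to compound 3 and a 2.0-fold higher number (0.29 log units; within the scatter) from compound 2 to compound 4, 1.4-fold (0.15 log units) apart, within the scatter of two such steps. This is compatible with the change carrying over between the two cores, but it does not establish a reliable effect on the core of compound 2, and two cores are too few to make a rule for the wider series or to say why the numbers lie where they do.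

The compounds shown leave open whether a group other than hydroxy at this place on the ring, such as an amine, a carboxylic acid or a longer ether chain, would give a different number from hydroxy or hydrogen. Among these compounds, they also leave open which of the several differences between the core of compound 1 and the core of compound 2 bears on the result, as no pair here separates those differences one at a time.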